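A few compounds are considered here, and "the series" means these few. Any claim that something is new, unique, unknown or untested is made for them only; others in the source may bear on it.

Numbers in an assay on mitochondria from L6 cells (Rattus norvegicus) for activation, with a stated time of 90 min (a higher number here means that more compound is needed for the effect, a lower number that less compound is needed), for the three measured compounds:

Compound 1, `CCCCOc1ccc(Nc2nc3nonc3nc2O)cc1`: 3700 nM
Compound 2, `Oc1nc2nonc2nc1Nc1ccc(SC(F)(F)F)cc1`: 1400 nM
Compound 3, `CC(C)(C)c1ccc(Nc2nc3nonc3nc2O)cc1`: 3900 nM

Two measured steps lead to compound 3: a 1.1-fold higher number from compound 1 to compound 3 (0.02 log units; within the scatter) and a 2.8-fold higher number from compound 2 to compound 3 (0.44 log units; beyond the scatter). The first is within the scatter, the second beyond it. Compound 3 therefore gives the highest of the three numbers in this assay, indistinguishable from compound 1 and set apart only from compound 2.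

The next compound in the series is compound 4, `CCCCc1ccc(Nc2nc3nonc3nc2O)cc1`. Its difference from compound 3 is butyl in place of tert-butyl on an aromatic carbon. The step that bears most directly on it is a 1.1-fold higher number from compound 1 to compound 3 (0.02 log units; within the scatter), a swap between two four-carbon groups at the same aromatic carbon that left the number within the scatter. The remaining steps, a 2.6-fold lower number from compound 1 to compound 2 (0.42 log units; beyond the scatter) and a 2.8-fold higher number from compound 2 to compound 3 (0.44 log units; beyond the scatter), each involve the (trifluoromethyl)sulfanyl group and say less about an exchange of one saturated four-carbon group for another. On that basis no step beyond the scatter is expected in this assay: a 1.1-fold lower number from compound 3 to compound 4 (0.05 log units; within the scatter). For compound 4 the estimate is 3500 nM, with a range from 1500 nM to 8000 nM.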

Compound 4, half-maximal effective concentration: 2100 nM
Compound 4: the middle estimate sits 1.7-fold (0.22 log units) above what was measured; low and high end bracket the measured number.
By their numbers in this assay, from the lowest: compounds 2, 4, 1 and 3 (each within the scatter of the next, the first and the last beyond it).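

At the aromatic carbon of compound 3, exchanging tert-butyl for butyl, two groups with the same atoms joined differently, stays within the scatter in this assay: a 1.9-fold lower number from compound 3 to compound 4 (0.27 log units; within the scatter). Butyl is also not separated from either of the other two groups at this carbon, a 1.8-fold lower number from compound 1 to compound 4 (0.25 log units; within the scatter) and a 1.5-fold higher number from compound 2 to compound 4 (0.18 log units; within the scatter), so compound 4 links the earlier gap between compound 2 and compounds 1 and 3 into one continuous set of numbers, although compounds 2 and 3 themselves remain apart. Nothing available here accounts for these numbers.

Still open, going by these compounds, is whether a carboxylic acid, an amine or a longer chain at this carbon would give a step clearly beyond the scatter from compound 4. On these data alone, how changes to the shared core would affect the number also remains open.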